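Dipropylamino to diallylamino on the methoxy-bearing core

The compounds below may be only part of what the source reports. "The series", "measured", "known", "first", "only" and "open" are said of these compounds alone.

Within the data shown here, compound 3 `CCCN(CCC)c1ccc(/C=C(\C#N)C(=O)O)c(OC)c1` gives 12 nM in an assay on RBE4 cells for inhibition of Monocarboxylate transporter 1 (Rattus norvegicus), with a stated time of 15 min (a higher number here means a weaker inhibitor, a lower number a stronger inhibitor), the second highest of the three numbers so far; it stands close to compound 1 `CCCN(CCC)c1ccc(/C=C(\C#N)C(=O)O)cc1`, which gives 10 nM, and far from compound 2 `C=CCN(CC=C)c1ccc(/C=C(\C#N)C(=O)O)cc1`, which gives 110 nM. Among the measured compounds shown here, the only single-point step measured is a 1.2-fold higher number from compound 1 to compound 3 (0.08 log units; within the scatter), so the methoxy group itself changes little. Compound 4 `C=CCN(CC=C)c1ccc(/C=C(\C#N)C(=O)O)c(OC)c1` differs from compound 3 by diallylamino in place of dipropylamino on an aromatic carbon. For the measured compounds named here, no step is recorded for this exact change, but compound 1 and compound 2 differ in the same way on the core without the methoxy group, and compound 2 gives a clearly higher number than compound 1 in this assay. Because the methoxy group added little in a 1.2-fold higher number from compound 1 to compound 3 (0.08 log units; within the scatter), the same exchange is expected to move compound 4 upward by a similar margin, as a 10-fold higher number from compound 3 to compound 4 (1.00 log units; beyond the scatter). Compound 4 is therefore estimated at 120 nM, within a range of 50 nM to 300 nM.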

Compound 4, half-maximal inhibitory concentration: 29 nM
Compound 4: middle estimate off by 4.1-fold (0.62 log units), on the high side; the whole stated range lies above it.
By their numbers in this assay, from the lowest: compounds 1 and 3 (each within the scatter of the next); then compound 4; then compound 2.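

In this assay, diallylamino in place of dipropylamino still raises the number on the methoxy-bearing core, but only as a 2.4-fold higher number from compound 3 to compound 4 (0.38 log units; beyond the scatter), a smaller rise than the printed values of the pair without methoxy suggest, with compound 1 at 10 nM and compound 2 at 110 nM. Methoxy in place of hydrogen, which seemed to do little with dipropylamino, matters with diallylamino, giving a 3.8-fold lower number from compound 2 to compound 4 (0.58 log units; beyond the scatter). The effect of the methoxy group thus depends on the amino group on the same ring, and the two cores do not respond alike: the same change on two cores in this assay, a 1.2-fold higher number (0.08 log units; within the scatter) from compound 1 to compound 3 and a 3.8-fold lower number (0.58 log units; beyond the scatter) from compound 2 to compound 4, 4.6-fold (0.66 log units) apart, beyond the scatter of two such steps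

Only two amino groups are shown, so it remains open whether diethylamino or dibutylamino would behave like dipropylamino or like diallylamino in this pairing. From the compounds shown here alone, it is also open whether an ethoxy group would match methoxy on either core.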